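The compounds below may be only part of what the source reports. "The series", "measured", "known", "first", "only" and "open" are said of these compounds alone.

Of the compounds shown here, three built on one shared core have been measured in an assay on isolated protein for binding affinity to Bile acid receptor (Homo sapiens), read by FRET; a higher number here means that more compound is needed for the effect, a lower number that less compound is needed. Compound 1 `CC(C)c1onc(-c2c(Cl)cccc2Cl)c1COc1ccc2c(ccn2Cc2cccc(C(=O)O)c2)c1` gives 320 nM in this assay. Compound 2 `CC(C)c1onc(-c2c(Cl)cccc2Cl)c1COc1ccc2c(ccn2Cc2ccc(C(=O)O)cc2)c1` gives 160 nM, and compound 3 `CC(C)c1onc(-c2c(Cl)cccc2Cl)c1COc1ccc2c(ccn2S(=O)(=O)c2cccc(C(=O)O)c2)c1` gives 160 nM. Compound 3 therefore stands level with compound 2 at the lowest of the three numbers, and its distance from the highest number is a 2.0-fold lower number from compound 1 to compound 3 (0.30 log units; within the scatter). The unmeasured compound 4 `CC(C)c1onc(-c2c(Cl)cccc2Cl)c1COc1ccc2c(ccn2C(=O)c2cccc(C(=O)O)c2)c1` differs from compound 3 in one place: (3-carboxyphenyl)carbonyl in place of (3-carboxyphenyl)sulfonyl on an aromatic nitrogen. Among the compounds with values here, the steps that bear on this change are the earlier exchanges of the group on the same aromatic nitrogen, a 2.0-fold lower number from compound 1 to compound 3 (0.30 log units; within the scatter) and no change at the digits printed from compound 2 to compound 3 (within the scatter), together with a 2.0-fold lower number from compound 1 to compound 2 (0.30 log units; within the scatter); each of these stayed within the scatter. Every exchange at that nitrogen has so far left the number essentially where it was, so the step in this assay is expected to stay within the scatter as well: a 1.3-fold higher number from compound 3 to compound 4 (0.10 log units; within the scatter). Compound 4 is accordingly estimated at 200 nM, with a range from 80 nM to 500 nM.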

Compound 4, half-maximal effective concentration: 150 nM
Estimate against measurement, compound 4: 1.3-fold (0.12 log units) above; low and high end bracket the measured number.
By their numbers in this assay, from the lowest: compounds 4, 2, 3 and 1 (each within the scatter of the next, the first and the last beyond it).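

At the aromatic nitrogen, (3-carboxyphenyl)carbonyl in place of (3-carboxyphenyl)sulfonyl leaves the number within the scatter in this assay (a 1.1-fold lower number from compound 3 to compound 4 (0.03 log units; within the scatter)), and the same holds for (3-carboxyphenyl)carbonyl in place of 4-carboxybenzyl (a 1.1-fold lower number from compound 2 to compound 4 (0.03 log units; within the scatter)). Against 3-carboxybenzyl, however, this group gives the first step at this position that lies beyond the scatter, though only a modest one (a 2.1-fold lower number from compound 1 to compound 4 (0.33 log units; beyond the scatter)), whereas the sulfonyl and 4-carboxybenzyl groups stayed within it. Nothing available explains these steps.

Still open is how (4-carboxyphenyl)carbonyl or (4-carboxyphenyl)sulfonyl would read on this nitrogen, since the compounds shown pair these linking groups with the 3-carboxyphenyl only. Also open, from the compounds shown here alone, is what a longer chain between the nitrogen and the ring would do, or an amine or a primary amide in place of the carboxylic acid.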